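Heptyl to 4-methylbenzyl on compound 3

The source may report more compounds than this note shows. Statements on the series, on what has been measured and on what is new or still open speak of the compounds shown alone.

Compound 3 `CCCCCCCc1nc(N)n(CC(=O)Nc2ccc(C)cc2)c1-c1ccccc1Br` gives 7000 nM in a functional assay on MIA PaCa-2 cells (Homo sapiens) for antiproliferative activity, read by MTT assay, with a stated time of 48 h (on this read-out higher numbers stand for weaker inhibition and lower numbers for stronger inhibition), the highest of the three numbers. Compound 1 `Nc1nc(Cc2ccccc2)c(-c2ccccc2Br)n1CC(=O)Nc1ccccc1` gives 5700 nM and sits within the scatter of that value, while compound 2 `COc1ccc(Cc2nc(N)n(CC(=O)Nc3ccccc3)c2-c2ccccc2Br)cc1` gives 3200 nM, beyond the scatter. Among the measured compounds shown here, the only single-place step measured is a 1.8-fold lower number from compound 1 to compound 2 (0.25 log units; within the scatter). Compound 4 `Cc1ccc(Cc2nc(N)n(CC(=O)Nc3ccc(C)cc3)c2-c2ccccc2Br)cc1` differs from compound 3 by 4-methylphenyl in place of hexyl on a saturated chain carbon bound to an aromatic carbon. For the measured compounds named here, no measured step exchanges a chain for an aromatic group, so the step from the benzyl pair bears only loosely: it shows that a substituent on the benzyl group moves the number little. Both benzyl compounds give numbers no higher than compound 3, and compound 2 lies clearly lower. Compound 4 is therefore expected to shift by a 2.0-fold lower number from compound 3 to compound 4 (0.30 log units; within the scatter). The estimate for compound 4 is 3500 nM, with a range of 1500 nM to 8000 nM.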

Compound 4, half-maximal inhibitory concentration: 2900 nM
Estimate against measurement, compound 4: 1.2-fold (0.08 log units) above; the range from low to high includes it.
By their numbers in this assay, from the lowest: compounds 4, 2, 1 and 3 (each within the scatter of the next, the first and the last beyond it).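

At the saturated chain carbon bound to an aromatic carbon, 4-methylphenyl in place of hexyl gives a 2.4-fold lower number from compound 3 to compound 4 (0.38 log units; beyond the scatter) in this assay. Among the compounds shown here, this is the first measured exchange of a chain for an aromatic group at this position, and the first single-place step beyond the scatter, though it is modest and rests on one pair. Nothing in hand bears on the reason for this step.

From the compounds shown here alone, whether the exchange holds with the unsubstituted phenyl amide of compounds 1 and 2 stays open. So does how a shorter chain, a cyclohexyl group or an amine would fare at this place.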